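The compounds below may be only part of what the source reports. "The series", "measured", "known", "first", "only" and "open" are said of these compounds alone.

Measured so far in a functional assay (aorta) for antagonist activity, with Oryctolagus cuniculus as the target; on this read-out lower numbers stand for stronger inhibition and higher numbers for weaker inhibition:
compound 1 `CCCCNC(=O)NCc1ccc(CCCC)n(Cc2ccc(-c3ccccc3-c3nn[nH]n3)cc2)c1=O`: 10 nM
compound 2 `CCCCc1ccc(CN(CC)S(C)(=O)=O)c(=O)n1Cc1ccc(-c2ccccc2-c2nn[nH]n2)cc1`: 2 nM

Compound 2 stands lowest of the two numbers in this assay; its nearest neighbour is compound 1, separated by a 5.0-fold lower number from compound 1 to compound 2 (0.70 log units; beyond the scatter). That step exchanged one substituent for another on the saturated chain carbon bound to an aromatic carbon, the only point at which the two structures differ.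

Compound 3 `CCCCc1ccc(C)c(=O)n1Cc1ccc(-c2ccccc2-c2nn[nH]n2)cc1` is not yet measured. It differs from compound 2 by hydrogen in place of ethyl(methylsulfonyl)amino on a saturated chain carbon bound to an aromatic carbon; cut one bond further out, the same difference reads (ethyl(methylsulfonyl)amino)methyl to methyl. Within the data shown here, the only measured step that touches this position is a 5.0-fold lower number from compound 1 to compound 2 (0.70 log units; beyond the scatter), and it shows that what sits on this carbon moves the number beyond the scatter. Among the measured compounds shown here, no measured compound carries a bare methyl here, so removal of the group outright has no direct precedent in this assay. The group that leaves is the one present in the lower of the two numbers, so its loss is expected to raise the number, a 7.5-fold higher number from compound 2 to compound 3 (0.88 log units; beyond the scatter), a modest step rather than none beyond the scatter. Compound 3 is therefore estimated at 15 nM, with a range from 3 nM to 75 nM.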

Compound 3, half-maximal inhibitory concentration: 7 nM
Compound 3: middle estimate off by 2.1-fold (0.33 log units), on the high side, within the range that was stated.
By their numbers in this assay, from the lowest: compound 2; then compounds 3 and 1 (each within the scatter of the next).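

In this assay the bare methyl of compound 3 gives this carbon its first reference point without an added group, and ethyl(methylsulfonyl)amino now separates from it beyond the scatter (a 3.5-fold higher number from compound 2 to compound 3 (0.54 log units; beyond the scatter)). The (butylcarbamoyl)amino group does not separate from that reference point, its step lying within the scatter (a 1.4-fold lower number from compound 1 to compound 3 (0.15 log units; within the scatter)), so the earlier difference between compound 1 and compound 2 no longer reads as two groups that both lower the number: only ethyl(methylsulfonyl)amino does so relative to hydrogen, and a large group on this carbon is not needed for a number in the range of compound 1. No measurement available here accounts for the different behaviour of the two groups.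

Which part of ethyl(methylsulfonyl)amino carries the step stays open, as the ethyl and the methylsulfonyl always occur together in these compounds. Also open, on these data alone, is where an amine, a carboxylic acid or a methylsulfonylamino group without the ethyl would stand on this carbon relative to compound 2 and compound 3.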